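Swapping a halogenated phenyl for 3-ethynylphenyl

A few compounds are considered here, and "the series" means these few. Any claim that something is new, unique, unknown or untested is made for them only; others in the source may bear on it.

- compound 1 `O=C(/C=C/c1ccccc1)Nc1cc2c(Nc3ccc(F)c(Cl)c3)ncnc2s1`: 22800 nM
- compound 2 `O=C(/C=C/c1ccccc1)Nc1cc2c(Nc3ccc(Cl)c(Cl)c3)ncnc2s1`: 30100 nM
- compound 3 `O=C(/C=C/c1ccccc1)Nc1cc2c(Nc3cccc(Cl)c3F)ncnc2s1`: 44600 nM

All three values come from a functional assay on HepG2 cells (Homo sapiens) for antiproliferative activity, read by MTT assay, with a stated time of 48 h (on this read-out lower numbers stand for stronger inhibition and higher numbers for weaker inhibition), and all three compounds share one core, differing only in the substituted phenyl group on a nitrogen. Compound 3 sits close to both others, with a 2.0-fold higher number from compound 1 to compound 3 (0.29 log units; within the scatter) and a 1.5-fold higher number from compound 2 to compound 3 (0.17 log units; within the scatter) on record. The remaining step is also small (a 1.3-fold higher number from compound 1 to compound 2 (0.12 log units; within the scatter)). Compound 4 `C#Cc1cccc(Nc2ncnc3sc(NC(=O)/C=C/c4ccccc4)cc23)c1` changes that same group (3-ethynylphenyl in place of 3-chloro-2-fluorophenyl on a nitrogen on an aromatic ring), which means 3-ethynylphenyl in place of 3-chloro-2-fluorophenyl on a nitrogen on an aromatic ring.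

For the measured compounds named here, no measured compound carries an ethynyl group, so the guide is indirect: the three steps so far all stay within the scatter. No step beyond the scatter is therefore expected in this assay, and the data give no firm direction. The expected move is modest (a 1.4-fold lower number from compound 3 to compound 4 (0.14 log units; within the scatter)). For compound 4 the estimated value is 32000 nM (expected range 13000 nM to 75000 nM).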

Compound 4, half-maximal inhibitory concentration: 58100 nM
Compound 4: the middle estimate sits 1.8-fold (0.26 log units) below what was measured; measured number inside the range.
By their numbers in this assay, from the lowest: compounds 1, 2, 3 and 4 (each within the scatter of the next, the first and the last beyond it).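

In this assay, a phenyl ring carrying an ethynyl group and no halogen cannot be told apart from two of the halogenated groups on this nitrogen (a 1.3-fold higher number from compound 3 to compound 4 (0.11 log units; within the scatter); a 1.9-fold higher number from compound 2 to compound 4 (0.29 log units; within the scatter)). The position now shows its first step beyond the scatter, a modest one, when 3-ethynylphenyl replaces 3-chloro-4-fluorophenyl (a 2.5-fold higher number from compound 1 to compound 4 (0.41 log units; beyond the scatter)). Nothing measured here explains this small difference.

As far as these compounds go, all four groups on this nitrogen are substituted phenyl rings, so the effect of an amine or a carboxylic acid on that ring, or of a longer chain in place of the ethynyl group, remains open. The shared core and its amide side chain are also the same throughout, so these steps say nothing about how changes there would read in this assay.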